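The source may hold more compounds than are shown below. What is called first, only, known or untested is meant among the compounds shown, and "the series" means these compounds.

Measured in a functional assay on the whole organism with Rattus norvegicus as the target; on this read-out higher numbers stand for an effect only at larger amounts of compound and lower numbers for an effect already at smaller amounts:
- compound 1 `CCN(CCNC(=O)c1cc(Cl)c(N)cc1OC)Cc1ccccc1OC`: 10 mg/kg
- compound 2 `CCN(CCNC(=O)c1cc(Cl)c(N)cc1OC)Cc1cccc(OC)c1`: 1 mg/kg

Of these two, compound 2 has the lower number, at 1 mg/kg, and the gap to compound 1 lies beyond the scatter.

The next compound is compound 3 `CCN(CCNC(=O)c1cc(Cl)c(N)cc1OC)Cc1ccc(OC)cc1`. It has 4-methoxyphenyl in place of 3-methoxyphenyl on a saturated chain carbon bound to an amine nitrogen. The rest of the structure is unchanged.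

Among the measured compounds shown here, only one measured step bears on this change: a 10-fold lower number from compound 1 to compound 2 (1.00 log units; beyond the scatter). That step is an exchange of the same kind at the same place, and it shows that such isomers need not read alike in this assay. For the measured compounds named here, no measured compound carries the 4-methoxyphenyl group, and a single step sets no trend, so direction remains uncertain. A moderate rise is expected, smaller than the step seen between the two measured isomers, and the range allows for no change or a small fall.

The expected change is a 3.0-fold higher number from compound 2 to compound 3 (0.48 log units; beyond the scatter).

For compound 3 the estimated value is 3 mg/kg, with an expected range of 0.8 mg/kg to 12 mg/kg.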

Compound 3, dose for half-maximal effect: 0.2 mg/kg
Beside the measured number, compound 3's estimate is 15-fold (1.18 log units) above it; the measured number lies below the stated range.
By their numbers in this assay, from the lowest: compound 3; then compound 2; then compound 1.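

With compound 3 in this assay, all three methoxyphenyl isomers at this place, on a saturated chain carbon bound to an amine nitrogen, can be compared, and the numbers fall in the order 2-methoxyphenyl, 3-methoxyphenyl, 4-methoxyphenyl, with none of the three going against that order. The earlier step now has a second one in the same direction, a 5.0-fold lower number from compound 2 to compound 3 (0.70 log units; beyond the scatter), and the full span of the set is a 50-fold lower number from compound 1 to compound 3 (1.70 log units; beyond the scatter), so moving the methoxy group around the ring, with the atoms unchanged, gives a large change and leaves compound 3 with the lowest number of the three. No supporting data accompany this result to explain the order among the isomers.

Open, going by these compounds, is whether the methoxy group itself is needed for the low number of compound 3, a question that a plain phenyl, an ethoxyphenyl or a hydroxyphenyl at the same place would address. Also open, on these data alone, is whether the order of the three isomers holds when the ethyl group on the amine nitrogen gives way to a methyl or a propyl group.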